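Changing the aromatic end of compound 2

The source may hold more compounds than are shown below. What is called first, only, known or untested is meant among the compounds shown, and "the series" means these compounds.

For the measured compounds named here, in a functional assay on HL-60 cells (Homo sapiens) for antiproliferative activity, read by MTT assay, with a stated time of 72 h (a higher number here means a weaker inhibitor, a lower number a stronger inhibitor), compound 2 (`NC1=NC2(CCSCC2)N(OCCCOc2cccc(Cl)c2Cl)C(N)=N1`) gives 30 nM, the lowest of the three numbers measured so far. Compound 1 (`NC1=NC2(CCOCC2)N(OCCCOc2ccc(Cl)cc2)C(N)=N1`) gives 330 nM and compound 3 (`Cc1ccc(OCCCON2C(N)=NC(N)=NC23CCOCC3)cc1`) gives 2580 nM, and both have a core different from that of compound 2. Compound 4 (`COc1ccc(OCCCON2C(N)=NC(N)=NC23CCSCC3)cc1`) keeps the core of compound 2 but differs by 4-methoxyphenyl in place of 2,3-dichlorophenyl on an oxygen on a saturated carbon. Going by the values given here, only one measured step bears on this change: a 7.8-fold higher number from compound 1 to compound 3 (0.89 log units; beyond the scatter), where methyl replaces chloro on an aromatic carbon. Among the compounds with values here, it also loses chlorine, though no methoxy compound has been measured. The expected step in this assay is therefore of similar size and towards a higher number: an 8.3-fold higher number from compound 2 to compound 4 (0.92 log units; beyond the scatter). For compound 4, the estimated value is 250 nM, with an expected range of 60 nM to 1000 nM.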

Compound 4, half-maximal inhibitory concentration: 500 nM
The estimate for compound 4 lay 2.0-fold (0.30 log units) below the measured number; the measured number falls inside the stated range.
By their numbers in this assay, from the lowest: compound 2; then compounds 1 and 4 (each within the scatter of the next); then compound 3.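

In this assay, for the compounds shown here, the swap of 2,3-dichlorophenyl for 4-methoxyphenyl gives a 17-fold higher number from compound 2 to compound 4 (1.22 log units; beyond the scatter) and is the first measured step at this position on the core of compound 2 that shows the aromatic end matters there too. This single step replaces both chlorines with one methoxy group, so it cannot show which part of the change accounts for the rise. Nothing measured here explains the size of this step.

Also open, as far as these compounds go, is whether a 4-chlorophenyl end on this core would stay close to compound 2. An aromatic amine, or a longer chain in place of the present one, is equally untested in the compounds shown.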